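A few compounds are considered here, and "the series" means these few. Any claim that something is new, unique, unknown or untested is made for them only; others in the source may bear on it.

Compound 1 `Cc1c(C(=O)N=C(N)N)cc(S(C)(=O)=O)c(Cl)c1C` gives 58 nM in a functional assay for inhibition of sodium/hydrogen exchanger (Oryctolagus cuniculus); a lower number here means a stronger inhibitor, a higher number a weaker inhibitor.
Compound 2 `Cc1cc(-c2ccc(Cl)cc2)c(S(C)(=O)=O)cc1C(=O)N=C(N)N` gives 45 nM in this assay.

Compound 2 stands together with compound 1: the gap between the two numbers lies within the scatter, so neither can be set apart from the other. Compound 3 `Cc1cc(Sc2ccccc2Cl)c(S(C)(=O)=O)cc1C(=O)N=C(N)N` differs from compound 2 in one place: (2-chlorophenyl)sulfanyl in place of 4-chlorophenyl on an aromatic carbon. Among the compounds with values here, no measured pair shows an exchange of this kind, so there is no step to lean on. The step expected here, a 1.3-fold higher number from compound 2 to compound 3 (0.12 log units; within the scatter), should not go beyond the scatter in either direction. The estimate for compound 3 in this assay is 60 nM, within 20 nM to 200 nM.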

Compound 3, half-maximal inhibitory concentration: 14 nM
The estimate for compound 3 lay 4.3-fold (0.63 log units) above the measured number; measured number outside the range, below it.
By their numbers in this assay, from the lowest: compound 3; then compounds 2 and 1 (each within the scatter of the next).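

In this assay the exchange of 4-chlorophenyl for (2-chlorophenyl)sulfanyl on the aromatic carbon ortho to a methylsulfonyl group gives a 3.2-fold lower number from compound 2 to compound 3 (0.51 log units; beyond the scatter) and so shows that the group at this position can move the number beyond the scatter. Two things change in this one exchange, the sulfur link and the place of the chlorine, and no measurement here explains the step. The compounds shown leave open which of the two carries the step, since neither 2-chlorophenyl nor (4-chlorophenyl)sulfanyl stands among them. Going by these compounds, how an amine or a carboxylic acid would fare at this position also remains open.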